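A few compounds are considered here, and "the series" means these few. Any claim that something is new, unique, unknown or untested is made for them only; others in the source may bear on it.

Within the data shown here, in a physicochemical assay for lipophilicity, using the shake flask method (on this read-out higher numbers stand for higher lipophilicity and lower numbers for lower lipophilicity), compound 2 (`CCCCO/N=C/c1c(N)ncnc1Oc1ccc(NC(=O)C2(C(=O)Nc3ccc(F)cc3)CC2)cc1F`) gives 4.2, the higher of the two numbers so far, while compound 1 (`Nc1ncnc(Oc2ccc(NC(=O)C3(C(=O)Nc4ccc(F)cc4)CC3)cc2F)c1/C=N/OCCO`) gives 2.37. Compound 3 (`CC(O)CO/N=C/c1c(N)ncnc1Oc1ccc(NC(=O)C2(C(=O)Nc3ccc(F)cc3)CC2)cc1F`) departs from compound 2 by one change: 1-hydroxyethyl in place of propyl on a saturated chain carbon bound to an oxygen on an unsaturated carbon. In words, this is 1-hydroxyethyl in place of propyl on a saturated chain carbon bound to an oxygen on an unsaturated carbon. Among the measured compounds shown here, only one measured step bears on it: a number 1.83 log units higher from compound 1 to compound 2 (beyond the scatter), where ethyl replaces hydroxy on a saturated chain carbon. The new change runs the other way, with a hydroxy group coming in, so a large fall is expected. Compound 3 differs from compound 1 in its chain, so the fall will probably not reach the full size of that single step. The expected change is a number 1.50 log units lower from compound 2 to compound 3 (beyond the scatter). For compound 3 the estimated value is 2.7, with an expected range of 2.3 to 3.2.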

Compound 3, partition coefficient: 2.75
Estimate against measurement, compound 3: 0.05 log units below; the measured number falls inside the stated range.
By their numbers in this assay, from the lowest: compound 1; then compound 3; then compound 2.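

In this assay the swap from propyl to 1-hydroxyethyl gives a number 1.45 log units lower from compound 2 to compound 3 (beyond the scatter) even though both groups have 3 heavy atoms, so the large difference on this chain no longer comes with a change in heavy-atom count. Methyl in place of hydrogen on the hydroxy-bearing chain gives a number 0.38 log units higher from compound 1 to compound 3 (beyond the scatter) and shows that this chain still responds to a small carbon addition, though only by a modest step. Nothing available here explains the size of either step.

The compounds shown leave open how an amine or a carboxylic acid on this chain would read in this assay. They also leave open whether a longer chain carrying a hydroxy group would follow compound 3 or move further towards compound 2.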